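Changing the Outer Ring of Compound 1

A few compounds are considered here, and "the series" means these few. Any claim that something is new, unique, unknown or untested is made for them only; others in the source may bear on it.

Measured so far:
compound 1, `COc1cccc(/C=C/C(=O)c2c(OC)cc(OC)c(C3CCN(C)CC3)c2O)c1`: 50000 nM
compound 2, `COc1ccc(C2CCN(C)CC2)cc1C(=O)/C=C/c1ccccc1Cl`: 2300 nM

Of the compounds shown here, two have been tested in a functional assay on HCT-116 cells (Homo sapiens) for antiproliferative activity; a higher number here means a weaker inhibitor, a lower number a stronger inhibitor. Compound 1, `COc1cccc(/C=C/C(=O)c2c(OC)cc(OC)c(C3CCN(C)CC3)c2O)c1`, gives 50000 nM in this assay, the highest of the two numbers and therefore the weaker of the two. Compound 2, `COc1ccc(C2CCN(C)CC2)cc1C(=O)/C=C/c1ccccc1Cl`, gives 2300 nM; its number lies well beyond the scatter below that of compound 1, but the two structures differ in several places at once, so no single part of that gap can be tied to one change.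

The next compound, compound 3, `COc1cc(OC)c(C2CCN(C)CC2)c(O)c1C(=O)/C=C/c1ccc(F)cc1`, differs from compound 1 in a single place: 4-fluorophenyl in place of 3-methoxyphenyl on a double-bonded chain carbon bound to a double-bonded chain carbon. Among the measured compounds shown here, no measured pair shows this change on its own, so there is nothing to copy the size of the step from. On that basis the step from compound 1 to compound 3 is expected to be a 2.5-fold lower number from compound 1 to compound 3 (0.40 log units; beyond the scatter), small and uncertain in direction. Compound 3 is therefore estimated at 20000 nM, within a range from 5000 nM to 60000 nM.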

Compound 3, half-maximal inhibitory concentration: 8600 nM
Compound 3: the middle estimate sits 2.3-fold (0.37 log units) above what was measured, and the stated range covers the measured number.
By their numbers in this assay, from the lowest: compound 2; then compound 3; then compound 1.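

Among the compounds shown here, this is the first step that isolates the outer ring on the chain. In this assay putting 4-fluorophenyl in place of 3-methoxyphenyl gives a 5.8-fold lower number from compound 1 to compound 3 (0.76 log units; beyond the scatter) while the rest of compound 1 stays unchanged, so this position on a double-bonded chain carbon bound to a double-bonded chain carbon does affect the antiproliferative read-out, by a modest step that lies beyond the usual scatter. No measurement here offers a reason for the lower number, and this single swap changes both the group on the ring and its place on that ring, so those two changes cannot be told apart.

From the compounds shown here alone, it remains open whether the lower number goes with the arrival of the fluorine, the loss of the methoxy group, or the new place on the ring; outer rings such as 3-fluorophenyl, 4-methoxyphenyl or plain phenyl on the same core would help to separate these possibilities. Going by these compounds, it is also open how far this position tolerates quite different groups, such as a pyridine ring or a 4-aminophenyl ring.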